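Ethyl in place of acetyl on compound 1

This account rests on a few compounds, and the source may have more. Where it says the series, first, only, none or still open, it means among the compounds named here.

Compounds measured in a functional assay (aorta) with Oryctolagus cuniculus as the target; on this read-out higher numbers stand for weaker binding and lower numbers for tighter binding:
- compound 1 `COc1cc(C(C)=O)ccc1OCCCN1CCC(C(c2ccc(F)cc2)c2ccc(F)cc2)CC1` gives 1.59 nM
- compound 2 `COc1cc(C(C)=O)ccc1OCCCN1CCC(C(c2ccc(F)cc2)c2ccccn2)CC1` gives 158 nM
- compound 3 `COc1cc(C(C)=O)ccc1OCCCN1CCC(Cc2ccc(F)cc2)CC1` gives 20 nM

Compound 1 has the lowest number of the three, with compound 3 the nearest and compound 2 the furthest. Compound 4 `CCc1ccc(OCCCN2CCC(C(c3ccc(F)cc3)c3ccc(F)cc3)CC2)c(OC)c1` has not yet been measured. It departs from compound 1 by ethyl in place of acetyl on an aromatic carbon.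

Among the measured compounds shown here, no measured step touches this place. All three steps alter the saturated chain carbon bound to an aromatic carbon and a saturated ring carbon: a 99-fold higher number from compound 1 to compound 2 (2.00 log units; beyond the scatter), a 13-fold higher number from compound 1 to compound 3 (1.10 log units; beyond the scatter) and a 7.9-fold lower number from compound 2 to compound 3 (0.90 log units; beyond the scatter). These large and modest steps show how far the numbers can move in this set, but they say nothing about acetyl or ethyl. Compound 1, at 1.59 nM, is the lowest seen, so a move upward is expected, though only a moderate one and with wide uncertainty. The expected change is a 2.5-fold higher number from compound 1 to compound 4 (0.40 log units; beyond the scatter). Compound 4 is estimated at 4 nM, within an expected range from 0.8 nM to 20 nM.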

Compound 4, dissociation constant: 2.51 nM
For compound 4 the middle estimate is 1.6-fold (0.20 log units) above the measured one; measured number inside the range.
By their numbers in this assay, from the lowest: compounds 1 and 4 (each within the scatter of the next); then compound 3; then compound 2.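

In this assay, among the compounds shown here, exchanging acetyl for ethyl at this aromatic carbon gives a 1.6-fold higher number from compound 1 to compound 4 (0.20 log units; within the scatter) and provides the first reading at this position. On the core of compound 1, with its two 4-fluorophenyl groups, the loss of the carbonyl and its hydrogen-bond acceptor therefore leaves a difference that this read-out does not resolve, unlike the steps at the saturated chain carbon, which all lie beyond the scatter. Nothing measured here accounts for this outcome.

The compounds shown leave open whether the same exchange would read alike on the cores of compound 2 and compound 3. They also leave open how an amine, a carboxylic acid or a longer chain such as butyl would read at this aromatic carbon.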